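Inversion at a ring stereocentre of compound 1

The compounds below may be only part of what the source reports. "The series", "measured", "known", "first", "only" and "open" are said of these compounds alone.

Compound 1 `COc1cc([C@H]2C[C@]2(CO)C(=O)Nc2ccccc2Cl)cc(OC)c1OC` gives in a functional assay on K562 cells (Homo sapiens) for cytotoxicity, read by MTT assay, with a stated time of 48 h (on this read-out lower numbers stand for stronger inhibition and higher numbers for weaker inhibition), only a limit, > 100000 nM. Compound 2 `COc1cc([C@H]2C[C@]2(CO)C(=O)NCc2ccc(C)cc2)cc(OC)c1OC`, carrying 4-methylbenzyl in place of 2-chlorophenyl on an amide-type nitrogen, likewise gives only a limit in this assay, > 100000 nM. The step that the two limits leave unreadable from compound 1 to compound 2 is thus not readable; both measurements fall under (the limit of > 100000 nM in this assay, at which 2 of the 2 values shown sit). Compound 3 `COc1cc([C@H]2C[C@@]2(CO)C(=O)Nc2ccccc2Cl)cc(OC)c1OC` differs from compound 1 by the two compounds have the same atoms and bonds and differ only in configuration as drawn: 1 of 2 stereo elements differ; a stereocentre at a saturated ring carbon is drawn S in compound 1 and R in compound 3. Among the measured compounds shown here, no measured step bears on a change of configuration at a saturated ring carbon, and compound 1 itself stands at a limit, so neither size nor direction can be read. Compound 3 is expected to stay at the limit too, with an estimated step that the limit leaves unreadable from compound 1 to compound 3. The estimate for compound 3 is 150000 nM, between 40000 nM and 500000 nM.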

Compound 3, half-maximal inhibitory concentration: > 100000 nM
Compound 3 gave a limit, no number (the forecaster's own chance of this, stated with the estimate: 80%); the middle value does not contradict the limit.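

Compounds 1 and 3 both stand at a limit, so no step between them can be read: the limit of > 100000 nM in this assay, at which 3 of the 3 values shown sit.

The compounds shown leave open whether configuration at this saturated ring carbon affects cytotoxicity at all, as none gives a number.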